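A few compounds are considered here, and "the series" means these few. Any claim that something is new, unique, unknown or untested is made for them only; others in the source may bear on it.

Going by the values given here, compound 2 `CCCCCc1ccc(NC(=O)N[C@H](C)c2ccccc2)cc1` is the weaker of the two compounds measured so far. In an ADME assay on the whole organism with Oryza sativa as the target, tested at 10 uM (a lower number here means a stronger effect, a higher number a weaker effect of the compound at the concentration tested), compound 2 gives 97%, the higher of the two numbers, meaning the weaker effect at the concentration tested. Its partner, compound 1 `C[C@@H](NC(=O)Nc1ccc(C(C)(C)C)cc1)c1ccccc1`, differs only in having tert-butyl instead of pentyl on an aromatic carbon; in this assay compound 1 gives 53%. Among the compounds with values here, the single measured step, a number 44 percentage points higher from compound 1 to compound 2 (beyond the scatter), shows that replacing the branched group with the straight chain weakened the effect well beyond the scatter. Compound 3 `CCCCCCCc1ccc(NC(=O)N[C@H](C)c2ccccc2)cc1` extends the same chain again: ethyl in place of hydrogen on a saturated chain carbon, five bonds along the chain from an aromatic carbon. Within the data shown here, only that one step bears on this change, and it points upward; yet compound 2 already sits close to the top of the scale, so little room is left for a further rise. Compound 3 is therefore expected to give about 95%, within 78% to 108%, an expected step of a number 2 percentage points lower from compound 2 to compound 3 (within the scatter).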

Compound 3, a percentage reported as activity, at one concentration (the size of the read-out at that concentration, not a potency): 100%
Compound 3: the middle estimate sits 5 percentage points below what was measured; measured number inside the range.
By their numbers in this assay, from the lowest: compound 1; then compounds 2 and 3 (each within the scatter of the next).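

Ethyl in place of hydrogen, five bonds along the chain from an aromatic carbon, gives a number 3 percentage points higher from compound 2 to compound 3 (within the scatter) in this assay, so lengthening pentyl to heptyl brings no change that can be told from the scatter. Set against tert-butyl, the heptyl chain gives a number 47 percentage points higher from compound 1 to compound 3 (beyond the scatter), which shows that the large gap from tert-butyl seen with pentyl also holds for a second, longer straight chain. Nothing available explains this gap or the flat step between the two straight chains.

As far as these compounds go, what a shorter straight chain such as propyl, or a ring such as cyclohexyl, would give on that aromatic carbon remains open. The compounds shown therefore cannot separate the effect of branching from that of chain length.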